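Methylating the phenol: a shared step, a new core

The source may hold more compounds than are shown below. What is called first, only, known or untested is meant among the compounds shown, and "the series" means these compounds.

Measured so far:
compound 1, `O=C(Nc1cccc(-n2cc(-c3ccncc3)c(-c3cc(O)cc(Cl)c3)n2)c1)Nc1ccc(Cl)c(Cl)c1`: -50.9%
compound 2, `COc1cc(Cl)cc(-c2nn(-c3cccc(NC(=O)Nc4ccc(Cl)c(Cl)c4)c3)cc2-c2ccncc2)c1`: 23.2%
compound 3, `O=C(Nc1cccc(-n2cc(-c3ccncc3)c(-c3cc(O)cc(Cl)c3)n2)c1)c1cc(C(F)(F)F)cc(C(F)(F)F)c1`: 63.6%

In a functional assay on SK-MEL-28 cells (Homo sapiens) for inhibition, read by sulforhodamine B assay, with a stated time of 48 h, tested at 10 uM (on this read-out higher numbers stand for a weaker effect at the one concentration tested and lower numbers for a stronger effect), compound 1 gives -50.9% and compound 2 gives 23.2%. The change between them is methyl in place of hydrogen on an oxygen on an aromatic ring, and the step it made is a number 74.1 percentage points higher from compound 1 to compound 2 (beyond the scatter).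

Compound 4, `COc1cc(Cl)cc(-c2nn(-c3cccc(NC(=O)c4cc(C(F)(F)F)cc(C(F)(F)F)c4)c3)cc2-c2ccncc2)c1`, has not yet been measured. It differs from compound 3 by methyl in place of hydrogen on an oxygen on an aromatic ring, the same change as from compound 1 to compound 2, made in the same place. How the core of compound 3 differs from the core of compound 1 is not broken down here. In this assay compound 3 gives 63.6%, already the highest of the three numbers.

Compound 4 is expected to sit higher than compound 3, with a step of about a number 21.4 percentage points higher from compound 3 to compound 4 (beyond the scatter), because the same change moved compound 1 to compound 2 by a number 74.1 percentage points higher from compound 1 to compound 2 (beyond the scatter); the estimate is kept smaller since compound 3 starts high and a read-out of this kind has little room left above it. The estimate for compound 4 is 85%, expected to fall between 60% and 110%.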

Compound 4, a percentage reported as activity, at one concentration (the size of the read-out at that concentration, not a potency): 78.8%
The estimate for compound 4 lay 6.2 percentage points above the measured number, within the range that was stated.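

In this assay, replacing hydroxy with methoxy gives a number 15.2 percentage points higher from compound 3 to compound 4 (beyond the scatter), so on this second core the change again shifts the read-out towards a weaker effect. The direction of the step carries over from one core to the other, but its size does not: the same change on two cores in this assay, a number 74.1 percentage points higher (beyond the scatter) from compound 1 to compound 2 and a number 15.2 percentage points higher (beyond the scatter) from compound 3 to compound 4, 58.9 percentage points apart, beyond the scatter of two such steps
Going by these compounds alone, with only two such pairs, this does not show why the size differs or how the change would behave on any further core.

The compounds shown carry only hydroxy or methoxy at this place, so the effect of a longer chain on the oxygen, such as ethoxy, remains open. Going by these compounds, replacing the oxygen group with an amine also remains untested here on either core.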